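A Second Chloro Added to Compound 3

The source may hold more compounds than are shown below. What is called first, only, known or untested is meant among the compounds shown, and "the series" means these compounds.

Measured so far in an ADME assay on cells (Mus musculus, strain Balb/c) for cytotoxicity, read by MTT assay, with a stated time of 48 h; on this read-out lower numbers stand for higher toxicity in this test and higher numbers for lower toxicity in this test:
compound 1 `O/N=C(\C=C\c1ccc(Cl)cc1)c1ccc(Cl)cc1` gives 14100 nM;
compound 2 `O/N=C(\C=C\c1ccc(Cl)c(Cl)c1)c1ccc(Br)cc1` gives < 5000 nM, a limit of the assay and not a number;
compound 3 `Cc1ccc(C(/C=C/c2ccc(Cl)cc2)=N/O)cc1` gives 21300 nM.

Compound 3 stands highest of the two numbers, with compound 1 nearest, and the step of a 1.5-fold higher number from compound 1 to compound 3 (0.18 log units; within the scatter) is within the scatter, so these two cannot be ranked. Compound 4 `Cc1ccc(C(/C=C/c2ccc(Cl)c(Cl)c2)=N/O)cc1` differs from compound 3 by chloro in place of hydrogen on an aromatic carbon. Among the measured compounds shown here, no measured step covers this change alone. Compound 2 also carries two chloro groups on one ring, yet it differs from compound 1 in a bromo as well. Compound 2 sits at the limit of < 5000 nM in this assay, at which 1 of the 3 values shown sits. Because compound 2 sits at the limit of < 5000 nM in this assay, at which 1 of the 3 values shown sits, a step of a 2.7-fold lower number from compound 3 to compound 4 (0.43 log units; beyond the scatter) toward a lower number is expected. Compound 4 is estimated at 8000 nM, between 3000 nM and 20000 nM.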

Compound 4, half-maximal cytotoxic concentration: 14700 nM
Beside the measured number, compound 4's estimate is 1.8-fold (0.26 log units) below it; the range from low to high includes it.
By their numbers in this assay, from the lowest: compounds 1, 4 and 3 (each within the scatter of the next). At a limit, below all of these: compound 2.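

In this assay, a second chloro on this ring, ortho to a chloro group, gives a 1.4-fold lower number from compound 3 to compound 4 (0.16 log units; within the scatter), so this change does not separate the two compounds. Among the compounds shown here, with that chloro present in both, methyl in place of bromo gives an at least 2.9-fold higher number from compound 2 to compound 4 (0.46 log units; beyond the scatter), the first step here beyond the scatter. Compound 2 stands at a limit of the assay and not at a number: the limit of < 5000 nM in this assay, at which 1 of the 4 values shown sits.

As far as these compounds go, what an amine or a carboxylic acid would do at this position stays open. So does the effect of a longer chain in place of the methyl.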